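Swapping methyl for chloro on a lipophilic compound

A few compounds are considered here, and "the series" means these few. Any claim that something is new, unique, unknown or untested is made for them only; others in the source may bear on it.

Values in a physicochemical assay for lipophilicity, in phosphate buffer, measured as octanol-water partition, at pH 11.5; a higher number here means a more lipophilic compound, a lower number a more polar compound:
- Compound 1 `CCCCCCCCNC(=N)NC(=N)Nc1ccc(C)cc1`: 4.93
- Compound 2 `CCCCOC(=N)NC(=N)Nc1ccc(Cl)cc1`: 3.32
- Compound 3 `CCCCS(=O)(=O)c1ccc(NC(=N)NC(=N)NCCCCCCNC(=N)NC(=N)Nc2ccc(S(=O)(=O)CCCC)cc2)cc1`: 3.1

Compound 1 stands highest of these three in this assay, and its gaps down to compound 2 and to compound 3 both lie beyond the scatter. Still unmeasured, compound 4 `CCCCCCCCNC(=N)NC(=N)Nc1ccc(Cl)cc1` differs from compound 1 in one place: chloro in place of methyl on an aromatic carbon.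

For the measured compounds named here, no measured pair here differs in only one place, so the data give no direct guide to this swap. One heavy atom replaces one heavy atom, with no change in rings or net charge, so only a small upward move is expected. The estimated step of a number 0.12 log units higher from compound 1 to compound 4 (within the scatter) is expected to stay within the scatter. Compound 4 is expected at 5.05 in this assay, with an estimated range from 4.7 to 5.4 as the likely span.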

Compound 4, partition coefficient: 5.13
For compound 4 the middle estimate is 0.08 log units below the measured one; the range from low to high includes it.
By their numbers in this assay, from the lowest: compounds 3 and 2 (each within the scatter of the next); then compounds 1 and 4 (each within the scatter of the next).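

In this assay the change from 4-methylphenyl to 4-chlorophenyl gives a number 0.20 log units higher from compound 1 to compound 4 (within the scatter) and this is the first pair shown that differs in one place. On this aromatic carbon, para to a large group, chloro and methyl therefore cannot be told apart by this measurement, at least in this one pair. Nothing shown gives a measured reason for this result.

Still open, going by these compounds, is what a carboxylic acid or a nitrile in the same place would give. Also open, on these data alone, is whether the same swap stays this small on a different core.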